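Replacing a Cinnamoyl Arm with an Arylurea in a Quinoline Series

A few compounds are considered here, and "the series" means these few. Any claim that something is new, unique, unknown or untested is made for them only; others in the source may bear on it.

Of the compounds shown here, three built on the same quinoline-bearing core have been tested in an ADME assay on L6 cells (Rattus norvegicus) for cytotoxicity, read by resazurin assay, with a stated time of 70 h; a higher number here means a weaker inhibitor, a lower number a stronger inhibitor. Compound 1 `COc1cc(NC(C)CCCNC(=O)/C=C/c2ccccc2)c2ncccc2c1` gives 18500 nM. Compound 2 `COc1cc(NC(C)CCCNC(=O)/C=C/c2ccccc2F)c2ncccc2c1`, which differs from it only by a fluoro in place of hydrogen on an aromatic carbon, gives 3500 nM, a step of a 5.3-fold lower number from compound 1 to compound 2 (0.72 log units; beyond the scatter). Compound 3 `COc1cc(NC(C)CCCNC(=O)NNC(=O)/C=C/c2ccc(Cl)cc2)c2ncccc2c1` gives 7300 nM and so stands second highest of the three numbers, above compound 2 and below compound 1.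

The next compound, compound 4 `COc1cc(NC(C)CCCNC(=O)NNC(=O)Nc2ccc(Cl)cc2)c2ncccc2c1`, is compound 3 with one change: (4-chlorophenyl)amino in place of 2-(4-chlorophenyl)ethenyl on a carbonyl carbon. Going by the values given here, no measured step in this set bears directly on such a swap; the one step available, from compound 1 to compound 2, concerns a fluoro substituent and a different part of the molecule, so it offers little guidance. With nothing to anchor a direction, the expectation for compound 4 in this assay is a step of no more than modest size either way, most likely within the scatter, written as a 1.2-fold higher number from compound 3 to compound 4 (0.09 log units; within the scatter). Compound 4 is therefore expected to give about 9000 nM, with a plausible range from 3000 nM to 30000 nM.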

Compound 4, half-maximal inhibitory concentration: 91900 nM
Estimate against measurement, compound 4: 10-fold (1.01 log units) below; the measured number lies above the stated range.
By their numbers in this assay, from the lowest: compound 2; then compound 3; then compound 1; then compound 4.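

In this assay the group on the carbonyl carbon turns out to matter a great deal: replacing 2-(4-chlorophenyl)ethenyl with (4-chlorophenyl)amino gives a 13-fold higher number from compound 3 to compound 4 (1.10 log units; beyond the scatter) and makes compound 4 much weaker than compound 3. The chlorine-bearing six-membered aromatic ring is present on both sides of this swap, so the large step goes with what joins that ring to the carbonyl carbon, where a carbon-carbon double bond gives way to a nitrogen carrying one hydrogen-bond donor. Nothing available here accounts for the size of this step.

On these data alone, it remains open whether the step follows from gaining the nitrogen or from losing the double bond, a question that a saturated two-carbon chain or an oxygen atom in the same place could help to separate. As far as these compounds go, it is also open whether the same swap would give a step of similar size with a methoxy group or a nitrile on the ring instead of the chlorine.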